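The compounds below may be only part of what the source reports. "The series", "measured", "known", "first", "only" and "open" are said of these compounds alone.

The starting point is compound 1 `O=C(CN1CCN(c2nnc(Cc3ccncc3)c3ccccc23)CC1)Nc1ccc(F)c(F)c1`, tested in a functional assay on A549 cells (Homo sapiens) for cytotoxicity, read by MTT assay, with a stated time of 72 h (on this read-out higher numbers stand for weaker inhibition and lower numbers for stronger inhibition), where compound 1 gives 3790 nM. Among the compounds with a reported number, compound 1 stands at the highest value. Its nearest neighbour is compound 3 `O=C(CN1CCN(c2nnc(Cc3ccccc3)c3ccccc23)CC1)Nc1ccc(F)c(C(F)(F)F)c1`, which in this assay gives 2480 nM; the gap between compound 1 and compound 3 lies within the usual scatter of repeated measurements, so the two cannot be ranked against each other. A third compound, compound 2 `Cc1ccc(F)cc1NC(=O)CN1CCN(c2nnc(Cc3ccccc3)c3ccccc23)CC1`, in this assay is reported only as "not active" (no number reported), with no number attached.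

The step under consideration leads from compound 1 to compound 4 `O=C(CN1CCN(c2nnc(Cc3ccncc3)c3ccccc23)CC1)Nc1cc(C(F)(F)F)ccc1Cl`. The change is confined to the group on the amide-type nitrogen, whose other neighbour is the carbonyl carbon: 2-chloro-5-(trifluoromethyl)phenyl in place of 3,4-difluorophenyl on an amide-type nitrogen. Going by the values given here, no measured pair in this set mirrors that change, so nothing in the data tells how large a shift to expect. With compound 3 at 2480 nM and compound 2 without a number, the range of outcomes seen among related compounds is wide. The expected step in this assay is therefore small, amounting to a 1.2-fold higher number from compound 1 to compound 4 (0.07 log units; within the scatter), a change not clearly beyond the scatter in either direction. For compound 4 the estimated value is 4500 nM, within a range from 1500 nM to 15000 nM.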

Compound 4, half-maximal inhibitory concentration: 1850 nM
Beside the measured number, compound 4's estimate is 2.4-fold (0.39 log units) above it; measured number inside the range.
By their numbers in this assay, from the lowest: compounds 4, 3 and 1 (each within the scatter of the next, the first and the last beyond it).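

On the amide-type nitrogen of the core of compound 1, placing 2-chloro-5-(trifluoromethyl)phenyl in place of 3,4-difluorophenyl gives a 2.0-fold lower number from compound 1 to compound 4 (0.31 log units; beyond the scatter) in this assay. Going by these compounds alone, this is the first step in the set that changes this one group while the rest of the molecule stays the same, and it shows that this position alone can move the number, although only modestly, and that an aromatic ring with more heavy atoms still gives a measurable value. Nothing available explains the shift, so the data cannot assign it to the chlorine, to the trifluoromethyl group, or to the loss of the two fluorines.

The change alters several ring substituents at once, so the compounds shown leave open what each one contributes, and whether the same swap would produce a similar step on the core of compound 3. They also leave open how the number would respond if the aromatic ring on this nitrogen carried a nitrile or a carboxylic acid, or gave way to a saturated ring such as cyclohexyl.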